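A Ring Swap at the Weak End of the Scale

The source may report more compounds than this note shows. Statements on the series, on what has been measured and on what is new or still open speak of the compounds shown alone.

In a functional assay on AN3-CA cells (Homo sapiens) for antiproliferative activity, read by MTT assay, with a stated time of 72 h (on this read-out lower numbers stand for stronger inhibition and higher numbers for weaker inhibition), compound 1 (`O=C(Nc1ccc(Cl)c(-c2nnc3c(Cl)cccn23)c1)c1ccc(C(F)(F)F)cc1Cl`) returned > 100000 nM as its result, and this is a limit of the assay, not a number. Sharing its core, compound 2 (`O=C(Nc1ccc(Cl)c(-c2nnc3c(Cl)cccn23)c1)c1cccc(Cl)c1`) gives 68400 nM in this assay as the only true number so far. Compound 3 (`O=C(Nc1ccc(Cl)c(-c2nnc3c(Cl)cccn23)c1)c1cccnc1Cl`) has not yet been measured. It differs from compound 2 in one place, on a carbonyl carbon whose other neighbours are an amide-type nitrogen, where 2-chloropyridin-3-yl stands in place of 3-chlorophenyl (2-chloropyridin-3-yl in place of 3-chlorophenyl on a carbonyl carbon). Among the measured compounds shown here, no measured pair shows what this swap does, so compound 2 at 68400 nM is the only anchor for the expectation. The expected change a 1.1-fold higher number from compound 2 to compound 3 (0.04 log units; within the scatter) is small and should stay within the usual scatter of this assay as a result, and compound 3 may well report only a limit. The estimated value for compound 3 is 75000 nM with an expected range of 30000 nM to 100000 nM on this measure.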

Compound 3, half-maximal inhibitory concentration: > 100000 nM
Compound 3 ended at the assay's limit; the forecaster's own chance of this, stated with the estimate: 40%; middle value at least 1.3-fold (0.12 log units) away from the limit.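

In this assay, among the compounds shown here, putting 2-chloropyridin-3-yl in place of 3-chlorophenyl on a carbonyl carbon gives an at least 1.4-fold higher number from compound 2 to compound 3 (0.16 log units; that floor lies within the scatter), which is the first direct reading of any change at this place, and it shows no sign of stronger inhibition, although that floor alone does not separate the two compounds. Compound 3 gives > 100000 nM, which is a limit of the assay and not a number, so the real size of the step may be larger and cannot be stated. Adding one hydrogen-bond acceptor to this ring therefore brought no gain that can be read here, and the step stays open-ended because the readings stop at a ceiling: the limit of > 100000 nM in this assay, at which 2 of the 3 values shown sit.

With only compound 2 giving a true number, the compounds shown do not reveal what stronger inhibition would look like at this place, since the ring on the carbonyl carbon carries chlorine in all three. As far as these compounds go, whether an amine or a carboxylic acid on that ring in place of chlorine would bring the value down into a clearly measurable range remains open.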